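Working notes: step from compound 3 to compound 4

A few compounds are considered here, and "the series" means these few. Any claim that something is new, unique, unknown or untested is made for them only; others in the source may bear on it.

Measured in a functional assay on MDA-MB-436 cells (Homo sapiens) for antiproliferative activity, read by MTT assay, with a stated time of 48 h; a higher number here means a weaker inhibitor, a lower number a stronger inhibitor:
- compound 1 `C=CS(=O)(=O)N1CCN(c2ccn3ncc(-c4ccccc4)c3n2)CC1` gives 19500 nM
- compound 2 `C=CS(=O)(=O)N1CCN(c2ncnc3sc(-c4ccc(N5CCN(C)CC5)cc4)cc23)[C@@H](C)C1` gives 6920 nM
- compound 3 `CN1CCN(c2ccc(-c3cc4c(N5CCN(S(=O)(=O)/C=C/c6ccccc6)CC5)ncnc4s3)cc2)CC1` gives 8670 nM

Compound 3 stands within the scatter of compound 2, and its number is lower than that of compound 1 by more than the scatter. Compound 4 `CN1CCN(c2ccc(-c3cc4c(N5CCN(C(=O)Nc6ccccc6)CC5)ncnc4s3)cc2)CC1` carries phenylcarbamoyl in place of (2-phenylethenyl)sulfonyl on an amine nitrogen in a ring in the otherwise unchanged structure. Going by the values given here, no measured step isolates this change. The expectation rests on compound 3 (8670 nM) alone, so no step beyond the scatter is expected in this assay, in either direction. The estimated step, a 1.1-fold lower number from compound 3 to compound 4 (0.03 log units; within the scatter), is correspondingly small. For compound 4 the expected value is 8000 nM (estimated range 3000 nM to 20000 nM).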

Compound 4, half-maximal inhibitory concentration: 7090 nM
For compound 4 the middle estimate is 1.1-fold (0.05 log units) above the measured one; the range from low to high includes it.
By their numbers in this assay, from the lowest: compounds 2, 4 and 3 (each within the scatter of the next); then compound 1.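

In this assay, going by these compounds alone, phenylcarbamoyl in place of (2-phenylethenyl)sulfonyl on the amine nitrogen in the ring gives a 1.2-fold lower number from compound 3 to compound 4 (0.09 log units; within the scatter), the first single-place comparison. At this position, the sulfonyl group and its double bonds can therefore be exchanged for a group carrying a hydrogen-bond donor with no change beyond the scatter. No measured evidence accounts for this result. On these data alone, it remains open whether any group on this nitrogen moves the number beyond the scatter. An acetyl or benzyl group, or a free amine hydrogen, would test this.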